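A Methyl on the Chain Carbon in Two Related Pairs

This account rests on a few compounds, and the source may have more. Where it says the series, first, only, none or still open, it means among the compounds named here.

Compound 1 `O=C(O)COc1ccc(NC(=O)COc2cccc(C(F)(F)F)c2)cc1F` and compound 2 `CC(Oc1cccc(C(F)(F)F)c1)C(=O)Nc1ccc(OCC(=O)O)c(F)c1` share one core and differ only in that compound 2 carries methyl in place of hydrogen on a saturated chain carbon bound to a carbonyl carbon and an oxygen on an aromatic ring. In a functional assay on CHO cells for agonist activity at Free fatty acid receptor 1 (Homo sapiens), read by FLIPR, tested at 100 nM (a higher number here means a stronger effect of the compound at the concentration tested, a lower number a weaker effect), compound 1 gives 11.4%, and compound 2 gives 12.7%; the step of a number 1.3 percentage points higher from compound 1 to compound 2 (within the scatter) is small. Compound 3 `Cc1ccc(C(C)C)cc1OCC(=O)Nc1ccc(OCC(=O)O)c(F)c1` rests on another core; the difference between the two cores is not broken down here. In this assay compound 3 gives 14.6%. Compound 4 `Cc1ccc(C(C)C)cc1OC(C)C(=O)Nc1ccc(OCC(=O)O)c(F)c1` arises from compound 3 by the same change, (methyl in place of hydrogen on a saturated chain carbon bound to a carbonyl carbon and an oxygen on an aromatic ring), at the same place. A similarly small step is expected here, a number 1.4 percentage points higher from compound 3 to compound 4 (within the scatter), because the earlier step of a number 1.3 percentage points higher from compound 1 to compound 2 (within the scatter) lay within the scatter. On that basis compound 4 is estimated to give about 16% in this assay, most likely between 8% and 25%.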

Compound 4, a percentage reported as activity, at one concentration (the size of the read-out at that concentration, not a potency) in the Free fatty acid receptor 1 assay: 19.4%
Beside the measured number, compound 4's estimate is 3.4 percentage points below it; low and high end bracket the measured number.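

In the Free fatty acid receptor 1 assay compound 4 gives 19.4%, and the methyl change gives a number 4.8 percentage points higher from compound 3 to compound 4 (within the scatter). Set beside each other, the two steps do not differ by more than the scatter allows: the same change on two cores in the Free fatty acid receptor 1 assay, a number 1.3 percentage points higher (within the scatter) from compound 1 to compound 2 and a number 4.8 percentage points higher (within the scatter) from compound 3 to compound 4, 3.5 percentage points apart, within the scatter of two such steps On both cores the step stays within the scatter at this single concentration, which shows that the change transfers here without a detectable difference but does not show that it would do so on any other core or reveal anything about potency.

As far as these compounds go, in a physicochemical assay for lipophilicity, using the shake flask method, at pH 7.4 (on this read-out higher numbers stand for higher lipophilicity and lower numbers for lower lipophilicity), compound 3 gives 0.47, and for compound 4 the entry is "not determined" (no result reported), so the step to compound 4 cannot be read and what the methyl does on this read-out remains open. Also open, from the compounds shown here alone, is how an ethyl group or an amine on the same chain carbon would compare.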